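The source may report more compounds than this note shows. Statements on the series, on what has been measured and on what is new or still open speak of the compounds shown alone.

Values so far in a functional assay on HEp-2 cells (Homo sapiens) for inhibition, read by MTT assay, with a stated time of 72 h; on this read-out lower numbers stand for stronger inhibition and higher numbers for weaker inhibition:
compound 1 `CCCO[C@@H]1C=CC(=O)[C@@H](CO)O1` gives 13400 nM
compound 2 `O=C1C=C[C@@H](OC2CCCC2)O[C@@H]1CO` gives 8000 nM
compound 3 `C#CCO[C@@H]1C=CC(=O)[C@@H](CO)O1` gives 15400 nM

The steps of a 1.1-fold higher number from compound 1 to compound 3 (0.06 log units; within the scatter) and a 1.9-fold higher number from compound 2 to compound 3 (0.28 log units; within the scatter) both stay within the scatter, so compound 3 is not separated from the other two in this assay on these numbers.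

The next member is compound 4 `C=CCO[C@@H]1C=CC(=O)[C@@H](CO)O1` with the change vinyl in place of ethynyl on a saturated chain carbon bound to an oxygen on a saturated carbon. The closest evidence is a 1.1-fold higher number from compound 1 to compound 3 (0.06 log units; within the scatter) for ethynyl in place of ethyl at that same place, which is within the scatter. Cyclopentyl in place of propyl gives a 1.7-fold lower number from compound 1 to compound 2 (0.22 log units; within the scatter) and also stays within it. Within the data shown here, these are only three compounds, and none of them carries vinyl.

No step beyond the scatter is expected in this assay and the expected step is a 1.1-fold lower number from compound 3 to compound 4 (0.06 log units; within the scatter) at most in size. For compound 4 the estimated value is 13500 nM with an expected range of 7500 nM to 24000 nM for a repeat measurement.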

Compound 4, half-maximal inhibitory concentration: 26100 nM
For compound 4 the middle estimate is 1.9-fold (0.29 log units) below the measured one, and the stated range ends below it.
By their numbers in this assay, from the lowest: compounds 2, 1, 3 and 4 (each within the scatter of the next, the first and the last beyond it).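

In this assay, vinyl in place of ethynyl on a saturated chain carbon bound to an oxygen on a saturated carbon gives a 1.7-fold higher number from compound 3 to compound 4 (0.23 log units; within the scatter), and vinyl in place of ethyl at that place gives a 1.9-fold higher number from compound 1 to compound 4 (0.29 log units; within the scatter), so the propyl, propargyl and allyl ethers remain unseparated. The series now has its first step beyond the scatter: allyl in place of cyclopentyl on the oxygen gives a 3.3-fold higher number from compound 2 to compound 4 (0.51 log units; beyond the scatter), a modest step showing that this group can register in the assay, although compound 1 and compound 3 each stay within the scatter of compound 2. Nothing available accounts for this step.

Going by these compounds, whether a cyclohexyl or benzyl group on this oxygen would follow cyclopentyl remains open. A longer chain such as butyl, or a chain ending in an amine, is equally untested among the compounds shown here.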